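The source may report more compounds than this note shows. Statements on the series, on what has been measured and on what is new or still open speak of the compounds shown alone.

Among the measured compounds shown here, in a functional assay on Jurkat cells (Homo sapiens) for inhibition (on this read-out lower numbers stand for stronger inhibition and higher numbers for weaker inhibition), compound 1 `CC(C)[C@H](NC(=O)COc1cccc2ccccc12)C(=O)N[C@@H](CC(=O)O)C(=O)COc1cc(C(F)(F)F)n(C)n1` gives 46000 nM, the only full number among the three measured compounds. Compound 2 `CC(C)[C@H](NC(=O)COc1cccc2ccccc12)C(=O)N[C@@H](CC(=O)O)C(=O)CSC1=NCCS1` reaches only the limit of the assay, > 200000 nM. Compound 3 `CC(C)[C@H](NC(=O)COc1cccc2ccccc12)C(=O)N[C@@H](CC(=O)O)C(=O)CSc1nc(-c2ccccc2)cs1` likewise stops at a limit, > 200000 nM. The two steps away from compound 1 can therefore only be read as lower bounds: an at least 4.3-fold higher number from compound 1 to compound 2 (0.63 log units; beyond the scatter) and an at least 4.3-fold higher number from compound 1 to compound 3 (0.63 log units; beyond the scatter). The step between the two weaker compounds, a step that the two limits leave unreadable from compound 2 to compound 3, cannot be sized because of the limit of > 200000 nM in this assay, at which 2 of the 3 values shown sit.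

Compound 4 `CC(C)[C@H](NC(=O)COc1cccc2ccccc12)C(=O)N[C@@H](CC(=O)O)C(=O)CSc1nnc(-c2ccccc2)o1` differs from compound 1 by (5-phenyl-1,3,4-oxadiazol-2-yl)sulfanyl in place of (1-methyl-5-(trifluoromethyl)-1H-pyrazol-3-yl)oxy on a saturated chain carbon bound to a carbonyl carbon. The nearest measured comparison is the change to compound 3, where a (4-phenyl-1,3-thiazol-2-yl)sulfanyl group entered in the same place, and that step was an at least 4.3-fold higher number from compound 1 to compound 3 (0.63 log units; beyond the scatter). A similar weakening, beyond the scatter, is expected for compound 4, meaning a 5.4-fold higher number from compound 1 to compound 4 (0.74 log units; beyond the scatter). Compound 4 is estimated at 250000 nM, within a range from 80000 nM to 800000 nM, and it may well be reported only as a limit.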

Compound 4, half-maximal inhibitory concentration: 150000 nM
For compound 4 the middle estimate is 1.7-fold (0.22 log units) above the measured one; low and high end bracket the measured number.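

Among the sulfur-linked groups on this saturated chain carbon, the (5-phenyl-1,3,4-oxadiazol-2-yl)sulfanyl group of compound 4 is the only one that gives a full number, so the size of the weakening can now be read: a 3.3-fold higher number from compound 1 to compound 4 (0.51 log units; beyond the scatter). Against the two sulfur-linked compounds without a full number, the printed floors are an at least 1.3-fold lower number from compound 3 to compound 4 (0.12 log units; that floor lies within the scatter) and an at least 1.3-fold lower number from compound 2 to compound 4 (0.12 log units; that floor lies within the scatter). The true size of these two steps cannot be read because compound 2 and compound 3 stop at a limit, not a number: the limit of > 200000 nM in this assay, at which 2 of the 4 values shown sit.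

As far as these compounds go, the sulfur link and the ring change together in the step from compound 1, and which of them carries the weakening stays open. A (5-phenyl-1,3,4-oxadiazol-2-yl)oxy group, or a methyl in place of the phenyl on the oxadiazole, would separate these effects.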